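The source may hold more compounds than are shown below. What is called first, only, known or untested is meant among the compounds shown, and "the series" means these compounds.

Compound 1 `O=C(CCCCC(S)CCS)Nc1ccc(F)cc1`: 28.2%
Compound 2 `Cc1cccc(NC(=O)CCCCC(S)CCS)c1`: 17.5%
Compound 3 `O=C(CCCCC(S)CCS)Nc1ccc([N+](=O)[O-])cc1`: not yet measured

Among the measured compounds shown here, in a functional assay on KB cells (Homo sapiens) for inhibition, read by MTT assay, with a stated time of 24 h, tested at 100 ug/mL (on this read-out lower numbers stand for less inhibition of growth and higher numbers for more inhibition of growth at the one concentration tested), compound 1 gives 28.2%, the higher of the two numbers so far. Compound 2 stands at 17.5%, beyond the scatter from compound 1.

Compound 3 departs from compound 1 by one change: nitro in place of fluoro on an aromatic carbon. This places nitro in place of fluoro on an aromatic carbon, para to a large group. For the measured compounds named here, the series offers no measured step for a change in one place, so the size of this step cannot be read from the data. No shift beyond the scatter is expected in this assay, and no direction is favoured with any confidence. The expected step is a number 2.2 percentage points lower from compound 1 to compound 3 (within the scatter). For compound 3 the estimated value is 26%, with an expected range of 11% to 43%.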

Compound 3, percent growth inhibition at one concentration: 41.1%
Beside the measured number, compound 3's estimate is 15.1 percentage points below it; the range from low to high includes it.
By their numbers in this assay, from the lowest: compound 2; then compound 1; then compound 3.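

In this assay, among the compounds shown here, nitro in place of fluoro on an aromatic carbon, para to a large group, gives a number 12.9 percentage points higher from compound 1 to compound 3 (beyond the scatter) and is the first step that can be read at one place. This position is therefore not silent in this assay: the exchange of a single fluorine atom for nitro, with its three heavy atoms and two hydrogen-bond acceptors, goes with more inhibition of growth at the one concentration tested. Nothing at hand bears on the reason for this step.

With only fluoro and nitro to compare at this carbon, two groups cannot show a trend, and an amine or a carboxylic acid there could fall on either side of them. On these data alone, whether the step holds on other cores or at other concentrations also stays open.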